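Replacing 4-methoxyphenyl with 3-bromophenyl in compound 2

The compounds below may be only part of what the source reports. "The series", "measured", "known", "first", "only" and "open" are said of these compounds alone.

- Compound 1 `COc1cccc(/C=C2\CCCCC2=O)c1OC` gives 720000 nM
- Compound 2 `COc1ccc(/C=C2\CCC/C(=C\c3cccc(OC)c3OC)C2=O)cc1` gives 401000 nM

For the measured compounds named here, both values come from an ADME assay on Vero cells (Chlorocebus sabaeus) for inhibition (on this read-out higher numbers stand for lower toxicity in this test and lower numbers for higher toxicity in this test), and lie within the usual scatter of each other, so compound 2 stands level with compound 1, the only other compound measured. Compound 3 `COc1cccc(/C=C2\CCC/C(=C\c3cccc(Br)c3)C2=O)c1OC` carries 3-bromophenyl in place of 4-methoxyphenyl on a double-bonded chain carbon bound to a double-bonded ring carbon. Going by the values given here, no measured pair differs in one place only, so the data offer no direct precedent for this change. The expected step, a 1.4-fold lower number from compound 2 to compound 3 (0.16 log units; within the scatter) in this assay, leans slightly towards a lower number but is not expected to exceed the scatter. This expectation starts from compound 2 at 401000 nM and remains uncertain. For compound 3 the estimated value is 280000 nM (expected range 90000 nM to 750000 nM).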

Compound 3, half-maximal cytotoxic concentration: 31500 nM
Compound 3: the middle estimate sits 8.9-fold (0.95 log units) above what was measured; measured number outside the range, below it.
By their numbers in this assay, from the lowest: compound 3; then compounds 2 and 1 (each within the scatter of the next).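

In this assay, for the compounds shown here, exchanging 4-methoxyphenyl for 3-bromophenyl on a double-bonded chain carbon bound to a double-bonded ring carbon gives a 13-fold lower number from compound 2 to compound 3 (1.10 log units; beyond the scatter) and so supplies the first comparison here of two compounds that differ in one place. It shows that this position is not indifferent to the group it carries: the number moves towards higher toxicity in this test, even though the group that leaves and the group that enters each hold one six-membered aromatic ring of carbon only. Nothing available explains the size of this step.

Going by these compounds, whether the step follows from the bromine or from the different place of substitution stays open, and 4-bromophenyl and 3-methoxyphenyl would separate the two. The compounds shown also leave open how this position responds to a phenyl ring carrying an amine or a carboxylic acid.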